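This account rests on a few compounds, and the source may have more. Where it says the series, first, only, none or still open, it means among the compounds named here.

Measured compounds:
- Compound 1, `Cc1cccc(NC(=O)Nc2ccc(Oc3nc(C)cc(C)n3)cc2)c1`: "not determined" (no result reported) in a functional assay on CNE-2 cells (Homo sapiens) for cytotoxicity, read by MTT assay, with a stated time of 3 days; a higher number here means a weaker inhibitor, a lower number a stronger inhibitor
- Compound 2, `Cc1cc(C)nc(Oc2ccc(NC(=O)Nc3ccc(F)cc3)cc2)n1`: 46900 nM

Compound 2 therefore holds the only number shown; compound 1 contributes no value to compare against, so nothing can be said about a step between them. Compound 3, `Cc1cc(C)nc(Oc2ccc(NC(=O)Nc3ccc(Cl)cc3Cl)cc2)n1`, differs from compound 2 by 2,4-dichlorophenyl in place of 4-fluorophenyl on an amide-type nitrogen. Among the compounds with values here, with no measured step of this kind available, the direction of change is uncertain; a moderate shift toward a stronger inhibitor is expected, though one that may not exceed the usual scatter. The step from compound 2 to compound 3 is estimated at a 2.3-fold lower number from compound 2 to compound 3 (0.37 log units; beyond the scatter). Compound 3 is expected to give 20000 nM in this assay, within a range of 5000 nM to 80000 nM.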

Compound 3, half-maximal inhibitory concentration: 38900 nM
Compound 3: the middle estimate sits 1.9-fold (0.29 log units) below what was measured, within the range that was stated.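

In this assay, 2,4-dichlorophenyl in place of 4-fluorophenyl on the amide-type nitrogen gives a 1.2-fold lower number from compound 2 to compound 3 (0.08 log units; within the scatter), so the two compounds cannot be told apart. This position therefore accepts a ring carrying two chlorine atoms instead of one fluorine atom with no readable difference in this measurement. No measurement shown offers an explanation for this result. Going by these compounds, what stays open is whether a different kind of group on this phenyl ring, such as an amine or a carboxylic acid, would give a step beyond the scatter.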